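From 4-Chlorophenyl to 2-Fluorophenyl: Compound 2 to Compound 3

The source may report more compounds than this note shows. Statements on the series, on what has been measured and on what is new or still open speak of the compounds shown alone.

Compound 1 `Nc1ncnn2c([C@@H]3O[C@H](CO)[C@@H](O)[C@H]3O)cc(-c3ccccc3)c12`: > 100000 nM (a limit)
Compound 2 `Nc1ncnn2c([C@@H]3O[C@H](CO)[C@@H](O)[C@H]3O)cc(-c3ccc(Cl)cc3)c12`: 40200 nM

In a functional assay on Z-138 cells (Homo sapiens) for antiproliferative activity, with a stated time of 72 h (on this read-out lower numbers stand for stronger inhibition and higher numbers for weaker inhibition), compound 1 reaches only the limit > 100000 nM. For the measured compounds named here, compound 2 gives 40200 nM, the only actual number here. Going by the values given here, the one measured step, an at least 2.4-fold lower number from compound 1 to compound 2 (0.39 log units; beyond the scatter), concerns chloro in place of hydrogen on an aromatic carbon. Compound 3 `Nc1ncnn2c([C@@H]3O[C@H](CO)[C@@H](O)[C@H]3O)cc(-c3ccccc3F)c12` changes the group again: 2-fluorophenyl in place of 4-chlorophenyl on an aromatic carbon. Among the compounds with values here, no measured step covers exchanging one halogen-bearing phenyl for another, so the step of a 1.5-fold higher number from compound 2 to compound 3 (0.17 log units; within the scatter) is expected to be small, likely within the scatter. Compound 3 is estimated at 60000 nM, between 20000 nM and 150000 nM.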

Compound 3, half-maximal inhibitory concentration: 95300 nM
The estimate for compound 3 lay 1.6-fold (0.20 log units) below the measured number; the range from low to high includes it.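

This position responds to which halogen-bearing phenyl it carries: 2-fluorophenyl in place of 4-chlorophenyl gives a 2.4-fold higher number from compound 2 to compound 3 (0.37 log units; beyond the scatter). Fluoro in place of hydrogen has no readable size, as an at least 1.0-fold lower number from compound 1 to compound 3 (0.02 log units; that floor lies within the scatter) offers only a floor. Compound 1 stands at a limit, not a number, which leaves that comparison open: the limit of > 100000 nM in this assay, at which 1 of the 3 values shown sits.

From the compounds shown here alone, the halogen and its place on the phenyl change together here, so which of the two matters stays open. A 4-fluorophenyl or 2-chlorophenyl group would separate the two.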